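Swapping Bromo for Methyl at One Aromatic Carbon

The compounds below may be only part of what the source reports. "The series", "measured", "known", "first", "only" and "open" are said of these compounds alone.

Compound 1 `C/C(=N\Nc1nc(-c2ccccc2)cs1)c1sc(-c2ccccc2)nc1C` was tested in a toxicity assay on HCT-116 cells (Homo sapiens) for cytotoxicity, read by MTT assay; a higher number here means a weaker inhibitor of growth, a lower number a stronger inhibitor of growth. In this assay compound 1 reaches only a limit, > 100 ug/mL. Compound 2 `C/C(=N\Nc1nc(-c2ccc(Br)cc2)cs1)c1sc(-c2ccccc2)nc1C` differs from compound 1 by bromo in place of hydrogen on an aromatic carbon, and in this assay compound 2 gives 55.6 ug/mL. That change is an at least 1.7-fold lower number from compound 1 to compound 2 (0.25 log units; that floor lies within the scatter); its size can only be bounded because of the limit of > 100 ug/mL in this assay, at which 1 of the 2 values shown sits. Within the data shown here, compound 2 therefore holds the only measured number here, the other value being a limit. Compound 3 `C/C(=N\Nc1nc(-c2ccc(C)cc2)cs1)c1sc(-c2ccccc2)nc1C` is not yet measured; it differs from compound 2 by methyl in place of bromo on an aromatic carbon. Among the measured compounds shown here, the single measured step concerns the same place but a different exchange, hydrogen to bromo, so it bears only loosely on a bromo-to-methyl swap. No step beyond the scatter is expected, the estimated change being a 1.2-fold higher number from compound 2 to compound 3 (0.07 log units; within the scatter). For compound 3 the expected value in this assay is 65 ug/mL, within a range from 30 ug/mL to 140 ug/mL.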

Compound 3, concentration for 50% growth inhibition: > 100 ug/mL
Compound 3 gave a limit, no number; the forecaster's own chance of this, stated with the estimate: 25%; middle value at least 1.5-fold (0.18 log units) away from the limit.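

In this assay compound 3 reaches only a limit, not a number. Of the three groups seen at this place on the six-membered aromatic ring, bromo is therefore the only one that gives a measured value, while hydrogen and methyl both leave the compound at the limit. Putting methyl in place of bromo gives an at least 1.7-fold higher number from compound 2 to compound 3 (0.25 log units; that floor lies within the scatter), so a real loss of growth inhibition is possible but not established, and the step from hydrogen to methyl cannot be read, with all these sizes limited for one reason: the limit of > 100 ug/mL in this assay, at which 2 of the 3 values shown sit.

On these data alone, it remains open whether a number at this place is special to bromo or would also appear with a chloro group, a methoxy group or an amine. As far as these compounds go, how far compound 1 and compound 3 lie beyond the limit also remains unknown.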